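Varying the amide end: compound 3 to compound 4

The source may hold more compounds than are shown below. What is called first, only, known or untested is meant among the compounds shown, and "the series" means these compounds.

Three measured compounds share one core and differ only in the substituent on the amide carbonyl. Compound 1 `CC(C)(C)OC(=O)NCCCNC(=O)CN1CN(c2ccccc2)C2(CCN(C(=O)c3ccc(C(C)(C)C)cc3)CC2)C1=O` gives 4500 nM in an assay on HEK293 cells for displacement of a labelled ligand from NPC1-like intracellular cholesterol transporter 1 (Homo sapiens); a higher number here means a weaker inhibitor, a lower number a stronger inhibitor. Compound 2 `CC(C)(C)c1ccc(C(=O)N2CCC3(CC2)C(=O)N(CC(=O)NCCN)CN3c2ccccc2)cc1` gives 7000 nM in this assay, and compound 3 `CC(C)(C)c1ccc(C(=O)N2CCC3(CC2)C(=O)N(CC(=O)N2CCC(O)CC2)CN3c2ccccc2)cc1` gives 4700 nM. Compound 3 stands second highest of the three numbers; its nearest neighbour is compound 1, with a 1.0-fold higher number from compound 1 to compound 3 (0.02 log units; within the scatter), and its furthest is compound 2, with a 1.5-fold lower number from compound 2 to compound 3 (0.17 log units; within the scatter). Every step seen so far sits within the scatter, including a 1.6-fold higher number from compound 1 to compound 2 (0.19 log units; within the scatter).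

Compound 4 `CC(C)(C)c1ccc(C(=O)N2CCC3(CC2)C(=O)N(CC(=O)N2CCCCC2CO)CN3c2ccccc2)cc1` carries 2-(hydroxymethyl)piperidin-1-yl in place of 4-hydroxypiperidin-1-yl on a carbonyl carbon. Among the measured compounds shown here, the steps that bear on this change are the two that also exchanged the amide substituent, a 1.0-fold higher number from compound 1 to compound 3 (0.02 log units; within the scatter) and a 1.5-fold lower number from compound 2 to compound 3 (0.17 log units; within the scatter), and neither left the scatter. No step beyond the scatter is therefore expected in this assay for compound 4, in either direction. Compound 4 is estimated at 5000 nM, with a range of 2000 nM to 12000 nM. The expected step behind that estimate is a 1.1-fold higher number from compound 3 to compound 4 (0.03 log units; within the scatter).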

Compound 4, half-maximal inhibitory concentration: 11800 nM
Compound 4: middle estimate off by 2.4-fold (0.37 log units), on the low side; low and high end bracket the measured number.
By their numbers in this assay, from the lowest: compounds 1, 3, 2 and 4 (each within the scatter of the next, the first and the last beyond it).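

In this assay, among the compounds shown here, the amide end is no longer flat: 2-(hydroxymethyl)piperidin-1-yl gives the first steps beyond the scatter, both modest (a 2.5-fold higher number from compound 3 to compound 4 (0.40 log units; beyond the scatter)) and (a 2.6-fold higher number from compound 1 to compound 4 (0.42 log units; beyond the scatter)). Against the (2-aminoethyl)amino amide, the same group stays within the scatter (a 1.7-fold higher number from compound 2 to compound 4 (0.23 log units; within the scatter)), so compound 4 separates from only two of the three earlier compounds. Nothing measured here explains the step from 4-hydroxypiperidin-1-yl to 2-(hydroxymethyl)piperidin-1-yl.

The exchange alters the ring substitution and the heavy-atom count together, and the compounds shown do not separate these two changes. Going by these compounds, whether the step follows the hydroxymethyl group itself or its ring position remains open, and 4-(hydroxymethyl)piperidin-1-yl or unsubstituted piperidin-1-yl on the same carbonyl carbon would bear on that question.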